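Trifluoromethyl position swaps on the shared core

This account rests on a few compounds, and the source may have more. Where it says the series, first, only, none or still open, it means among the compounds named here.

Within the data shown here, compound 1 `CN(C(=O)NC(=O)c1cccc(C(F)(F)F)c1)c1nc(C(F)(F)F)c(C(=O)N/N=C/c2ccc(C(F)(F)F)cc2)s1` is the only compound of the pair with a numeric result: in a functional assay on HepG2 cells (Homo sapiens) for inhibition, read by MTT assay, with a stated time of 72 h (on this read-out higher numbers stand for weaker inhibition and lower numbers for stronger inhibition), compound 1 gives 7.71 ug/mL. Compound 2 `CN(C(=O)NC(=O)c1ccc(C(F)(F)F)cc1)c1nc(C(F)(F)F)c(C(=O)N/N=C/c2ccc(C(F)(F)F)cc2)s1` reaches only a limit of the assay, > 100 ug/mL, and sits at the limit of > 100 ug/mL in this assay, at which 1 of the 2 values shown sits. Among the measured compounds shown here, the single measured step, an at least 12-fold higher number from compound 1 to compound 2 (1.11 log units; beyond the scatter), shows that moving the trifluoromethyl around the ring on the carbonyl carbon is not tolerated. Compound 3 `CN(C(=O)NC(=O)c1cccc(C(F)(F)F)c1)c1nc(C(F)(F)F)c(C(=O)N/N=C/c2cccc(C(F)(F)F)c2)s1` makes the mirror-image change at the other end of the core: 3-(trifluoromethyl)phenyl in place of 4-(trifluoromethyl)phenyl on a carbon with a double bond to nitrogen. For the measured compounds named here, no measured pair covers the hydrazone ring, and the one step known concerns a different ring and the opposite direction of the swap, so it bears only loosely on this change. The default expectation is therefore a step of a 1.0-fold higher number from compound 1 to compound 3 (0.02 log units; within the scatter), with wide uncertainty. Compound 3 is estimated at 8 ug/mL, expected between 2 ug/mL and 40 ug/mL.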

Compound 3, half-maximal inhibitory concentration: 5.79 ug/mL
For compound 3 the middle estimate is 1.4-fold (0.14 log units) above the measured one, and the stated range covers the measured number.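

In this assay, the ring on a carbon with a double bond to nitrogen accepts 3-(trifluoromethyl)phenyl in place of 4-(trifluoromethyl)phenyl with no change beyond the scatter: a 1.3-fold lower number from compound 1 to compound 3 (0.12 log units; within the scatter). The swap in the opposite direction on a carbonyl carbon gave a step beyond the scatter, an at least 12-fold higher number from compound 1 to compound 2 (1.11 log units; beyond the scatter), so among these compounds the trifluoromethyl position matters on that ring and not on the ring at the other end of the core. No measured property shown here accounts for this difference between the two rings.

Still open, on these data alone, is whether a methoxy group or an amine in place of trifluoromethyl would be accepted on the ring at the carbon with a double bond to nitrogen. As far as these compounds go, compound 2 stands at a limit of the assay, > 100 ug/mL, so the full size of its step remains unknown.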